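From Ethoxy to Chloro in an Antiproliferative Series

The source may hold more compounds than are shown below. What is called first, only, known or untested is meant among the compounds shown, and "the series" means these compounds.

In a functional assay on SGC-7901 cells (Homo sapiens) for antiproliferative activity, read by MTT assay, with a stated time of 48 h (on this read-out lower numbers stand for stronger inhibition and higher numbers for weaker inhibition), compound 1 `COc1ccc(-c2nnc(SCc3ccc(Cl)nc3)o2)cc1` gives 3.5 ug/mL and compound 2 `CCOc1ccccc1-c1nnc(SCc2ccc(Cl)nc2)o1` gives 10.3 ug/mL, the higher of the two numbers and beyond the scatter from compound 1. Compound 3 `Clc1ccc(CSc2nnc(-c3ccccc3Cl)o2)cn1` carries chloro in place of ethoxy on an aromatic carbon, ortho to a large group (chloro in place of ethoxy on an aromatic carbon). Among the measured compounds shown here, no step between measured compounds differing in one place is available as a guide. A small move towards a lower number, within the scatter, is expected, the estimated step being a 1.5-fold lower number from compound 2 to compound 3 (0.17 log units; within the scatter). For compound 3 the expected value in this assay is 7 ug/mL, with an estimated range of 2.5 ug/mL to 20 ug/mL.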

Compound 3, half-maximal inhibitory concentration: 13.5 ug/mL
Compound 3: middle estimate off by 1.9-fold (0.29 log units), on the low side; the measured number falls inside the stated range.
By their numbers in this assay, from the lowest: compound 1; then compounds 2 and 3 (each within the scatter of the next).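

Among the compounds shown here, this is the only comparison here between compounds differing in one place. With ethoxy leaving and chloro entering on an aromatic carbon, ortho to a large group, this assay shows a 1.3-fold higher number from compound 2 to compound 3 (0.12 log units; within the scatter), so it does not tell these two groups apart at this position. Nothing available accounts for this result. As far as these compounds go, whether an amine or a carboxylic acid on the same carbon would also stay within the scatter of compound 2 remains open. So does what a longer chain than ethoxy would give there.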